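The source may hold more compounds than are shown below. What is called first, only, known or untested is meant among the compounds shown, and "the series" means these compounds.

Of the compounds shown here, three built on a shared core have been tested in a functional assay on NCI-H460 cells (Homo sapiens) for cytotoxicity, read by MTT assay, with a stated time of 72 h; on this read-out higher numbers stand for weaker inhibition and lower numbers for stronger inhibition. Compound 1 `COc1ccc(/C=N/NC(=O)Nc2ccc(Oc3ccnc(-c4nncn4CCN(C)C)c3)c(F)c2)c(OC)c1` gives 1570 nM, compound 2 `CN(C)CCn1cnnc1-c1cc(Oc2ccc(NC(=O)N/N=C/c3ccc(O)c(Br)c3)cc2F)ccn1` gives 430 nM, and compound 3 `CN(C)CCn1cnnc1-c1cc(Oc2ccc(NC(=O)N/N=C/c3ccc(Cl)cc3)cc2F)ccn1` gives 320 nM. Compound 2 thus holds the second highest of the three numbers: the step of a 1.3-fold lower number from compound 2 to compound 3 (0.13 log units; within the scatter) lies within the scatter, whereas the step of a 3.7-fold lower number from compound 1 to compound 2 (0.56 log units; beyond the scatter) lies beyond it. Compound 4 `COc1cc(/C=N/NC(=O)Nc2ccc(Oc3ccnc(-c4nncn4CCN(C)C)c3)c(F)c2)ccc1O` has not been measured; it differs from compound 2 by methoxy in place of bromo on an aromatic carbon. Both measured steps concern groups on this same six-membered aromatic ring of carbon only, and the larger of them was only modest. Compound 4 keeps the hydroxy group of compound 2 while gaining a methoxy, a group also found in compound 1. A small move toward a higher number is therefore expected, a 1.5-fold higher number from compound 2 to compound 4 (0.18 log units; within the scatter). Compound 4 is estimated at 650 nM, with a likely range from 250 nM to 1700 nM.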

Compound 4, half-maximal inhibitory concentration: 57 nM
Estimate against measurement, compound 4: 11-fold (1.06 log units) above, outside the stated range (below it).
By their numbers in this assay, from the lowest: compound 4; then compounds 3 and 2 (each within the scatter of the next); then compound 1.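

In this assay, methoxy in place of bromo, ortho to a hydroxy group, gives a 7.5-fold lower number from compound 2 to compound 4 (0.88 log units; beyond the scatter) and shows that this spot on the ring can shift the number strongly. The 4-hydroxy-3-methoxyphenyl group also outdoes 4-chlorophenyl, with a 5.6-fold lower number from compound 3 to compound 4 (0.75 log units; beyond the scatter) and 2,4-dimethoxyphenyl, with a 28-fold lower number from compound 1 to compound 4 (1.44 log units; beyond the scatter) so methoxy alone does not give a low number, as compound 1 also carries methoxy. No measurement here explains the change. Still open, going by these compounds, is how an ethoxy group or an amine would read at this position, and whether the low number of compound 4 needs its hydroxy group.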